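This account rests on a few compounds, and the source may have more. Where it says the series, first, only, none or still open, it means among the compounds named here.

Measured compounds:
compound 1, `COc1ccc(C[C@H]2C(=O)OC[C@@H]2Cc2ccccc2)cc1OC`: > 100000 nM
compound 2, `COc1cc(C[C@H]2C(=O)OC[C@@H]2Cc2ccccc2)cc(OC)c1OC`: > 100000 nM
compound 3, `Oc1ccc(C[C@H]2COC[C@@H]2Cc2ccc(Cl)c(Cl)c2)cc1`: 31000 nM

All three were tested in a functional assay on HL-60 cells (Homo sapiens) for cytotoxicity, read by WST assay, with a stated time of 48 h; on this read-out lower numbers stand for an effect already at smaller amounts and higher numbers for an effect only at larger amounts of compound. For compound 1 the value > 100000 nM is a limit of the assay and not a number. For compound 2 the value > 100000 nM is likewise a limit. Compound 2 differs from compound 1 by methoxy in place of hydrogen on an aromatic carbon; the step that the two limits leave unreadable from compound 1 to compound 2 cannot be sized, since the limit of > 100000 nM in this assay, at which 2 of the 3 values shown sit, holds for both. Going by the values given here, compound 3 gives 31000 nM, the only plain number here. How the core of compound 3 differs from that of compound 1 is not broken down here.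

Compound 4, `COc1cc(C[C@H]2COC[C@@H]2Cc2ccc(Cl)c(Cl)c2)ccc1O`, has not been measured; it differs from compound 3 by methoxy in place of hydrogen on an aromatic carbon. This is the same kind of change as from compound 1 to compound 2, but the surroundings differ: in compound 4 the new group sits ortho to a hydroxy group and meta to a large group, whereas in compound 2 it sits ortho to a methoxy group, meta to a large group and meta to a methoxy group. The measured pair gives no readable size for this change, so the expectation rests on the value of compound 3, 31000 nM. For compound 4 only a small step, a 1.1-fold higher number from compound 3 to compound 4 (0.05 log units; within the scatter), is expected. Compound 4 is therefore estimated at 35000 nM, between 10000 nM and 100000 nM.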

Compound 4, half-maximal effective concentration: 21000 nM
Compound 4: middle estimate off by 1.7-fold (0.22 log units), on the high side; low and high end bracket the measured number.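

In this assay, putting methoxy in place of hydrogen on an aromatic carbon, ortho to a hydroxy group, gives a 1.5-fold lower number from compound 3 to compound 4 (0.17 log units; within the scatter), so on this core the change cannot be told apart from the ordinary spread of repeated measurements. On the core of compound 1 the same kind of change cannot be read, because compound 1 and compound 2 both rest on a limit of the assay and not on a number: the limit of > 100000 nM in this assay, at which 2 of the 4 values shown sit. Going by these compounds alone, the series therefore offers only one readable pair, and it does not show whether the change would behave alike on both cores, only that nothing beyond the scatter appears on the core of compound 3.

As far as these compounds go, it remains open whether a different group on this aromatic carbon, such as an amine, a carboxylic acid or a longer chain like ethoxy, would shift the number beyond the scatter. Also open, from the compounds shown here alone, is how much each difference between the core of compound 1 and that of compound 3 contributes, since those compounds differ in more than one place.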